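From a Methylphenyl to a Fluorophenyl Amine Substituent

The source may hold more compounds than are shown below. What is called first, only, known or untested is meant among the compounds shown, and "the series" means these compounds.

Two measured compounds share one core and differ only in the group on an amine nitrogen in a ring. Compound 1 `CCCn1c(=O)[nH]c2nc(-c3ccc(S(=O)(=O)N4CCN(Cc5cccc(Br)c5)CC4)cc3)[nH]c2c1=O` carries a 3-bromobenzyl group there, and in an assay on CHO cells for displacement of a labelled ligand from adenosine receptor A1 (Homo sapiens), read by scintillation counting, with a stated time of 90 min, in the presence of a further agent that is not named here (on this read-out higher numbers stand for weaker inhibition and lower numbers for stronger inhibition), compound 1 gives 928 nM. Compound 2 `CCCn1c(=O)[nH]c2nc(-c3ccc(S(=O)(=O)N4CCN(c5ccc(C)cc5)CC4)cc3)[nH]c2c1=O` carries a 4-methylphenyl group instead. For compound 2 the assay reports only a limit, > 1000 nM. The step of an at least 1.0-fold higher number from compound 1 to compound 2 (0.03 log units; that floor lies within the scatter) therefore has only a floor, and that floor lies within the scatter, as the limit of > 1000 nM in this assay, at which 1 of the 2 values shown sits, shows. Compound 3 `CCCn1c(=O)[nH]c2nc(-c3ccc(S(=O)(=O)N4CCN(c5cccc(F)c5)CC4)cc3)[nH]c2c1=O` is not yet measured; it differs from compound 2 by 3-fluorophenyl in place of 4-methylphenyl on an amine nitrogen in a ring. Among the compounds with values here, no measured step exchanges one aromatic group for another on this nitrogen, so the only guide is where compound 2 stands, at the limit of > 1000 nM in this assay, at which 1 of the 2 values shown sits, in this assay. On that basis compound 3 is expected to give about 1500 nM in this assay, with a range from 500 nM to 5000 nM. That estimate means a step that the limit leaves unreadable from compound 2 to compound 3 that is expected to stay within the scatter, with a fair chance that only a limit is again reported.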

Compound 3, inhibition constant: > 1000 nM
Compound 3: a limit, no number (the forecaster's own chance of this, stated with the estimate: 60%); the middle value does not contradict the limit.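

In this assay compound 3 gives > 1000 nM, which is a limit and not a number. Within the data shown here, with 3-fluorophenyl on this amine nitrogen in a ring, as with 4-methylphenyl, the assay again returns no number, and the values now gather at one limit: the limit of > 1000 nM in this assay, at which 2 of the 3 values shown sit. The step between those two limits cannot be read, and the only readable step, an at least 1.0-fold higher number from compound 1 to compound 3 (0.03 log units; that floor lies within the scatter), gives no evidence that 3-fluorophenyl and 3-bromobenzyl differ at this position.

As far as these compounds go, how far compound 2 and compound 3 each lie beyond the limit stays open, and so does whether exchanging 4-methylphenyl for 3-fluorophenyl changes the binding at all. Also open, from the compounds shown here alone, is whether a 3-fluorobenzyl group, which would separate the fluorine from the bromine in the comparison with compound 1, or a phenyl ring bearing a carboxylic acid, would give a number in this assay.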